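Aryl swap on the shared core of compound 1

This account rests on a few compounds, and the source may have more. Where it says the series, first, only, none or still open, it means among the compounds named here.

Measured in a functional assay on HepG2 cells (Homo sapiens) for antiproliferative activity, read by XTT assay, with a stated time of 72 h; on this read-out lower numbers stand for stronger inhibition and higher numbers for weaker inhibition:
compound 1 `COc1ncnc2c1c(-c1ccsc1)cn2[C@@H]1O[C@H](CO)[C@@H](O)[C@H]1O` gives 430 nM.
Compound 2 `CN(C)c1ncnc2c1c(-c1ccsc1)cn2[C@@H]1O[C@H](CO)[C@@H](O)[C@H]1O` gives > 20000 nM, a limit of the assay.
Compound 3 `COc1nc(N)nc2c1c(-c1ccsc1)cn2[C@@H]1O[C@H](CO)[C@@H](O)[C@H]1O` gives > 20000 nM, a limit of the assay.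

Compound 1 holds the only number shown; the other two values are limits, both sitting at the limit of > 20000 nM in this assay, at which 2 of the 3 values shown sit. The two measured steps, an at least 46-fold higher number from compound 1 to compound 2 (1.66 log units; beyond the scatter) and an at least 46-fold higher number from compound 1 to compound 3 (1.66 log units; beyond the scatter), change groups on the six-membered ring of the core, not the aryl group on the five-membered ring.

Compound 4 `COc1ncnc2c1c(-c1ccccc1)cn2[C@@H]1O[C@H](CO)[C@@H](O)[C@H]1O` differs from compound 1 by phenyl in place of thiophen-3-yl on an aromatic carbon. Among the measured compounds shown here, no measured step touches this position, so neither large step is taken as a guide; the change is expected to stay within the scatter. For compound 4 the estimate is 600 nM (range 200 nM to 2500 nM), an expected step of a 1.4-fold higher number from compound 1 to compound 4 (0.14 log units; within the scatter).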

Compound 4, half-maximal inhibitory concentration: > 20000 nM
Compound 4: a limit, no number; the forecaster's own chance of this, stated with the estimate: 10%; middle value at least 33-fold (1.52 log units) away from the limit.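

At this position the aryl group is not interchangeable: phenyl in place of thiophen-3-yl gives an at least 46-fold higher number from compound 1 to compound 4 (1.66 log units; beyond the scatter). Among the compounds shown here, the aryl group on the five-membered ring, which no earlier step touched, therefore matters as much to the read-out as being able to move it beyond the scatter shows. The value of compound 4 is a limit, not a number, so the true size of this step stays unread, and compound 1 alone has a number: the limit of > 20000 nM in this assay, at which 3 of the 4 values shown sit.

The compounds shown leave open whether the sulfur atom or the ring size separates thiophen-3-yl from phenyl. Furan-3-yl on the same carbon would bear on that question.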